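A few compounds are considered here, and "the series" means these few. Any claim that something is new, unique, unknown or untested is made for them only; others in the source may bear on it.

Compound 1, `NC(=S)N/N=C1/C(=O)N(CN2CCN(c3ccnc4cc(C(F)(F)F)ccc34)CC2)c2cccc(Cl)c21`, gives 23000 nM in a functional assay on MDA-MB-468 cells (Homo sapiens) for cytotoxicity, read by sulforhodamine B assay, with a stated time of 48 h; on this read-out lower numbers stand for stronger inhibition of growth and higher numbers for weaker inhibition of growth. Compound 2, `NC(=S)N/N=C1/C(=O)N(CN2CCN(c3ccnc4cc(C(F)(F)F)ccc34)CC2)c2cccc(Br)c21`, gives 30400 nM in this assay. The two differ by bromo in place of chloro on an aromatic carbon, and the step is a 1.3-fold higher number from compound 1 to compound 2 (0.12 log units; within the scatter). Compound 3, `NC(=S)N/N=C1\C(=O)Nc2cc(Cl)ccc21`, gives 17700 nM in this assay; the difference between the core of compound 3 and the core of compound 1 is not broken down here, and the values of compound 3 and compound 1, as of compound 3 and compound 2, lie within the scatter of each other.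

Compound 4, `NC(=S)N/N=C1\C(=O)Nc2cc(Br)ccc21`, has not been measured. It differs from compound 3 by bromo in place of chloro on an aromatic carbon. This is the same kind of change as that from compound 1 to compound 2, though the surroundings differ: in compound 2 the bromo sits ortho to a fused ring and meta to a fused ring, while in compound 4 it sits meta to a fused ring and para to a fused ring. Because the earlier step was a 1.3-fold higher number from compound 1 to compound 2 (0.12 log units; within the scatter), a step of similar size is expected from compound 3 to compound 4, namely a 1.2-fold higher number from compound 3 to compound 4 (0.09 log units; within the scatter). On that basis compound 4 is estimated at 22000 nM, likely between 11000 nM and 45000 nM.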

Compound 4, concentration for 50% growth inhibition: 18600 nM
Beside the measured number, compound 4's estimate is 1.2-fold (0.07 log units) above it, within the range that was stated.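

In this assay, bromo in place of chloro on an aromatic carbon gives a 1.1-fold higher number from compound 3 to compound 4 (0.02 log units; within the scatter). Set beside the earlier step, the change carries from one core to the other with no difference that can be told apart: the same change on two cores in this assay, a 1.3-fold higher number (0.12 log units; within the scatter) from compound 1 to compound 2 and a 1.1-fold higher number (0.02 log units; within the scatter) from compound 3 to compound 4, 1.3-fold (0.10 log units) apart, within the scatter of two such steps This shows only that neither core gives a step beyond the scatter for this exchange of halogens; it does not show that the change has a real effect of a common size, and two pairs of compounds, which also differ in where the halogen sits, are too few to support a rule for the series.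

The compounds shown carry only chloro or bromo at this place, so it remains open how a fluoro, a methoxy, an amine or a carboxylic acid there would compare on either core. Also open, from the compounds shown here alone, is whether the match between the two steps would hold on any other cell line.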